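The compounds below may be only part of what the source reports. "The series", "measured", "known", "first", "only" and "open" are said of these compounds alone.

Measured in a functional assay on CHO cells for agonist activity at G-protein coupled receptor 39 (Homo sapiens), read by calcium flux; a higher number here means a larger maximal response, a lower number a smaller maximal response:
compound 1 `N#Cc1ccc(N2CCN(Cc3cn4cc(Cl)ccc4n3)CC2)nc1` — 48%
compound 2 `CNc1nc(Oc2ccccc2)cc(-c2ccccn2)n1` — 58%

In this assay compound 2 gives 58%, the higher of the two numbers, though compound 1 sits within the scatter of it, so the two cannot be ordered. Compound 3 `CNc1nc(NC2CCCCC2)cc(-c2ccccn2)n1` has not yet been measured. It differs from compound 2 in one place: cyclohexylamino in place of phenoxy on an aromatic carbon. For the measured compounds named here, no comparable step between measured compounds is available, so the size of the change is open. Compound 3 is estimated at 55%, with a range from 30% to 80%. The expected step of a number 3 percentage points lower from compound 2 to compound 3 (within the scatter) is small, likely within the scatter, in no firm direction.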

Compound 3, largest response reached (Emax), in percent of the reference or control that the assay uses: 49%
The estimate for compound 3 lay 6 percentage points above the measured number, and the stated range covers the measured number.
By their numbers in this assay, from the lowest: compounds 1, 3 and 2 (each within the scatter of the next).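

In this assay, cyclohexylamino in place of phenoxy on this aromatic carbon gives a number 9 percentage points lower from compound 2 to compound 3 (within the scatter). For this pair, a six-membered non-aromatic carbon ring with a nitrogen link and a hydrogen-bond donor therefore reads the same as a six-membered aromatic carbon ring with an oxygen link, so the aromatic ring is not needed here to retain this level of response. Nothing available explains why the two groups read alike. Still open, going by these compounds, is whether a morpholine, a carboxylic acid or a longer alkyl chain at this position would move the response beyond the scatter.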